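A few compounds are considered here, and "the series" means these few. Any claim that something is new, unique, unknown or untested is made for them only; others in the source may bear on it.

In a functional assay on SW-620 cells (Homo sapiens) for cytotoxicity, read by MTT assay, with stated times of 4 h and 72 h, tested at 5 uM (on this read-out lower numbers stand for stronger inhibition and higher numbers for weaker inhibition), compound 1 (`Cc1cc(Nc2ccc(C(=O)/C=C/c3ccc4ccccc4c3)cc2)n2nc(SCc3ccc([N+](=O)[O-])cc3)nc2n1`) gives 1130 nM and compound 2 (`Cc1cc(Nc2ccc(C(=O)/C=C/c3ccc4ccccc4c3)cc2)n2nc(SCc3cccc(C(F)(F)F)c3)nc2n1`) gives 2070 nM. These two values lie within the scatter of each other, so compound 2 has no distinct standing in this small set.

The unmeasured compound 3 (`Cc1cc(Nc2ccc(C(=O)/C=C/c3ccc4ccccc4c3)cc2)n2nc(SCc3ccccc3[N+](=O)[O-])nc2n1`) keeps the shared core and differs from compound 2 at one place: 2-nitrophenyl in place of 3-(trifluoromethyl)phenyl on a saturated chain carbon bound to a sulfur. In words, 2-nitrophenyl stands in place of 3-(trifluoromethyl)phenyl on a saturated chain carbon bound to a sulfur.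

Within the data shown here, only one measured step bears on this change: a 1.8-fold higher number from compound 1 to compound 2 (0.26 log units; within the scatter). It swaps 4-nitrophenyl for 3-(trifluoromethyl)phenyl at that same place and stays within the scatter. Among the measured compounds shown here, no measured compound yet carries 2-nitrophenyl, so the evidence is thin and the range must stay wide.

With that single small step as the guide, no change beyond the scatter is expected in this assay. The expected step, a 1.4-fold lower number from compound 2 to compound 3 (0.14 log units; within the scatter), is estimated to remain within the scatter. For compound 3 the estimated value is 1500 nM, with an expected range from 700 nM to 3200 nM.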

Compound 3, half-maximal inhibitory concentration: 960 nM
Compound 3: the middle estimate sits 1.6-fold (0.19 log units) above what was measured; measured number inside the range.
By their numbers in this assay, from the lowest: compounds 3, 1 and 2 (each within the scatter of the next, the first and the last beyond it).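

Among these compounds, on the saturated chain carbon bound to a sulfur, 2-nitrophenyl in place of 3-(trifluoromethyl)phenyl gives the first step in this assay to pass the scatter, though only modestly (a 2.2-fold lower number from compound 2 to compound 3 (0.33 log units; beyond the scatter)). The two nitrophenyl groups at this place are not told apart by this read-out (a 1.2-fold lower number from compound 1 to compound 3 (0.07 log units; within the scatter)), so the data give no sign that 2-nitrophenyl and 4-nitrophenyl differ here. No measurement accompanies these numbers that could account for the step, and its origin stays unexplained.

A simple reading that nitrophenyl groups give lower numbers than 3-(trifluoromethyl)phenyl rests on compound 3 alone, and compound 1 goes against it, since its step to compound 2 stays within the scatter. Still open, as far as these compounds go, is how far this place tolerates quite different groups, such as a phenyl ring bearing an amine or a carboxylic acid, or a longer chain in place of the benzyl, and whether the modest step seen in this one cell assay would hold up in any other read-out.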